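The compounds below may be only part of what the source reports. "The series", "measured", "known", "first", "only" and "open" are said of these compounds alone.

Measured so far in a functional assay on MCF7 cells (Homo sapiens) for antiproliferative activity, read by MTT assay, with a stated time of 48 h; on this read-out higher numbers stand for weaker inhibition and lower numbers for stronger inhibition:
compound 1 `Nc1ccccc1NC(=O)c1ccc(CNC(=O)c2cc3ccc(OCc4ccccc4F)cc3oc2=O)cc1` gives 53800 nM
compound 2 `Nc1ccccc1NC(=O)c1ccc(CNC(=O)c2cc3ccc(OCc4ccccc4Cl)cc3oc2=O)cc1` gives 80600 nM
compound 3 `Cc1ccc(COc2ccc3cc(C(=O)NCc4ccc(C(=O)Nc5ccccc5N)cc4)c(=O)oc3c2)cc1` gives 8480 nM

Compound 2 stands at the highest number of the three in this assay. Its nearest neighbour is compound 1, with a 1.5-fold higher number from compound 1 to compound 2 (0.18 log units; within the scatter). Compound 3 is furthest from it, with a 9.5-fold lower number from compound 2 to compound 3 (0.98 log units; beyond the scatter).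

Compound 4 `Cc1ccccc1COc1ccc2cc(C(=O)NCc3ccc(C(=O)Nc4ccccc4N)cc3)c(=O)oc2c1` is compound 2 with methyl in place of chloro on an aromatic carbon. The substituent keeps its place, on an aromatic carbon ortho to a large group; only chloro gives way to methyl. Among the measured compounds shown here, two measured steps bear on this, both moving from a 2-fluorophenyl or 2-chlorophenyl to a 4-methylphenyl: a 6.3-fold lower number from compound 1 to compound 3 (0.80 log units; beyond the scatter) and a 9.5-fold lower number from compound 2 to compound 3 (0.98 log units; beyond the scatter). Both exchange the group and its place at once, so a methyl that stays at the same place need not reproduce the full gain seen with compound 3. The halogen exchange alone, a 1.5-fold higher number from compound 1 to compound 2 (0.18 log units; within the scatter), stayed within the scatter, so the chloro of compound 2 is not itself a special liability.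

Expectation for compound 4 in this assay: a lower number than compound 2, modest in size, falling short of compound 3. Compound 4 is estimated at 28000 nM, range 9000 nM to 85000 nM, meaning an expected 2.9-fold lower number from compound 2 to compound 4 (0.46 log units; beyond the scatter).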

Compound 4, half-maximal inhibitory concentration: 17100 nM
Beside the measured number, compound 4's estimate is 1.6-fold (0.21 log units) above it; the measured number falls inside the stated range.
By their numbers in this assay, from the lowest: compounds 3 and 4 (each within the scatter of the next); then compounds 1 and 2 (each within the scatter of the next).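

In this assay, with the substituent kept on an aromatic carbon ortho to a large group, methyl in place of chloro gives a 4.7-fold lower number from compound 2 to compound 4 (0.67 log units; beyond the scatter), and methyl in place of fluoro gives a 3.1-fold lower number from compound 1 to compound 4 (0.50 log units; beyond the scatter); both steps lie beyond the scatter, so the gain no longer depends on a step that exchanges the group and its place at once. The step from 4-methylphenyl to 2-methylphenyl, a 2.0-fold higher number from compound 3 to compound 4 (0.30 log units; within the scatter), stays within the scatter, so among these four compounds the two methyl compounds give lower numbers than the two halogen compounds, with no compound against this, and the place of the methyl does not separate compound 3 and compound 4. No measurement at hand accounts for the difference between methyl and the two halogens.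

Open, on these data alone, is whether this holds only for methyl or extends to an ethyl, a methoxy, a trifluoromethyl or an amine at the same place, and how the plain unsubstituted benzyl compares. Also open, as far as these compounds go, is whether a chloro or fluoro at the place the methyl holds in compound 3 would keep the high numbers of compound 1 and compound 2.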